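The source may report more compounds than this note shows. Statements on the series, on what has been measured and on what is new or still open speak of the compounds shown alone.

Measured compounds:
- compound 1, `O=C(/C=C/c1ccc(Br)cc1)c1cccc(-c2cccc(F)c2)c1`: > 50000 nM
- compound 2, `COc1ccc(/C=C/C(=O)c2cccc(-c3cccc(F)c3)c2)cc1O`: 9590 nM
- compound 3, `COc1ccc(/C=C/C(=O)c2cccc(Br)c2)cc1`: > 50000 nM

All three values come from an assay on A549 cells for inhibition of transcription factor p65 (Homo sapiens), read by fluorescence, with a stated time of 2 h; a higher number here means a weaker inhibitor, a lower number a stronger inhibitor. Compound 3 does not have a number here: the result > 50000 nM is a limit of the assay, meaning no inhibition strong enough to be measured was seen. It shares this position with one other compound, as the evidence shows: the limit of > 50000 nM in this assay, at which 2 of the 3 values shown sit. Compound 1 also sits at a limit, > 50000 nM, and so is not a number either. Compound 2 is the only one of the three with a measured number, 9590 nM, which places it as a weak but measurable inhibitor.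

The next compound, compound 4, `COc1ccc(/C=C/C(=O)c2cccc(-c3cccc(F)c3)c2)cc1`, is reached from compound 3 by a single change: 3-fluorophenyl in place of bromo on an aromatic carbon. Within the data shown here, no measured pair in this set shows this same change, so its size cannot be read from a recorded step.

Compound 4 is expected to give 25000 nM, within 6000 nM to 80000 nM, because compound 2 gives 9590 nM and is the nearest measured structure. The step from compound 3 to compound 4 is therefore estimated as an at least 2.0-fold lower number from compound 3 to compound 4 (0.30 log units; that floor lies within the scatter), with a real chance that only a limit is reported again.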

Compound 4, half-maximal inhibitory concentration: > 50000 nM
Compound 4: a limit, no number; the forecaster's own chance of this, stated with the estimate: 45%; middle value at least 2.0-fold (0.30 log units) from the limit.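

Putting 3-fluorophenyl in place of bromo does not bring compound 4 off the limit in this assay, and the steps from compound 3 and from compound 1 cannot be read, with limits at both ends. The readable comparison is with compound 2, where the hydroxy group turns out to matter: hydrogen in its place gives an at least 5.2-fold higher number from compound 2 to compound 4 (0.71 log units; beyond the scatter). Among these compounds, the 3-fluorophenyl group comes with a measured number only in compound 2, which also carries the hydroxy group, while compound 1 and compound 4 lack the hydroxy group and the set now sits mostly at one limit: the limit of > 50000 nM in this assay, at which 3 of the 4 values shown sit.

From the compounds shown here alone, how far compound 4 really lies past that limit stays unknown, so the step from compound 2 gives only a floor for the loss, not its full size. Also open, going by these compounds, is whether the hydroxy group would give a measurable number with bromo in place of 3-fluorophenyl, and whether an amine or a carboxylic acid in place of that hydroxy group would keep, improve or lose the value of compound 2, 9590 nM.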